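From 4-Chlorobenzyl to 2-Chlorobenzyl

The source may report more compounds than this note shows. Statements on the series, on what has been measured and on what is new or still open speak of the compounds shown alone.

In a physicochemical assay for lipophilicity (on this read-out lower numbers stand for lower lipophilicity and higher numbers for higher lipophilicity), compound 1 `N#Cc1cccc(S(=O)(=O)N(Cc2ccc(F)cc2)C[C@@H]2CCC(=O)N2)c1` gives 2.7 and compound 2 `N#Cc1ccc(S(=O)(=O)N(Cc2ccc(F)cc2)C[C@@H]2CCC(=O)N2)cc1` gives 2.6 while compound 3 `N#Cc1cccc(S(=O)(=O)N(Cc2ccc(Cl)cc2)C[C@@H]2CCC(=O)N2)c1` stands highest of the three at 3.1 in this series. Compound 4 `N#Cc1cccc(S(=O)(=O)N(Cc2ccccc2Cl)C[C@@H]2CCC(=O)N2)c1` is still unmeasured. It keeps the same atoms as compound 3 but joins them differently, with 2-chlorophenyl in place of 4-chlorophenyl on a saturated chain carbon bound to a sulfonamide nitrogen and the rest unchanged.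

Within the data shown here, no measured step makes this exact change. The nearest guide is a step of the same kind, 4-cyanophenyl in place of 3-cyanophenyl on a sulfonyl sulfur, which gave a number 0.10 log units lower from compound 1 to compound 2 (within the scatter) in these data. The step with chloro in place of fluoro on an aromatic carbon gave a number 0.40 log units higher from compound 1 to compound 3 (beyond the scatter) but exchanges one atom for another, so it bears less directly.

Only a small step is expected in this assay and the estimate is a number 0.10 log units lower from compound 3 to compound 4 (within the scatter) with no shift beyond the scatter foreseen. Compound 4 is expected at 3 within a range of 2.7 to 3.3 on this estimate.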

Compound 4, distribution coefficient: 2.7
Estimate against measurement, compound 4: 0.30 log units above, within the range that was stated.
By their numbers in this assay, from the lowest: compounds 2, 1 and 4 (each within the scatter of the next); then compound 3.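

In this assay, among these compounds, the only earlier exchange of one isomer for another, on the cyanophenyl group at the sulfonyl sulfur, stayed within the scatter, whereas at this place, on a saturated chain carbon bound to a sulfonamide nitrogen, 2-chlorophenyl in place of 4-chlorophenyl gives a number 0.40 log units lower from compound 3 to compound 4 (beyond the scatter) with no change in the atoms present. The rise seen with chloro in place of fluoro therefore belongs to the 4-chlorophenyl compound alone among these, since 2-chlorophenyl in place of 4-fluorophenyl gives no change at the digits printed from compound 1 to compound 4 (within the scatter) in the same assay. The data offer no independent measurement that would account for this difference.

Going by these compounds, whether the gap between the two chlorophenyl groups is special to chlorine stays open, since a methoxy group or an amine in that place could behave differently. On these data alone, it is also open whether the same exchange would give a similar step on the 4-cyanophenyl compound 2.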